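The source may hold more compounds than are shown below. What is called first, only, known or untested is meant among the compounds shown, and "the series" means these compounds.

For the measured compounds named here, in a physicochemical assay for lipophilicity, using the shake flask method, at pH 7.4 (a higher number here means a more lipophilic compound, a lower number a more polar compound), compound 1 `CCCC(Oc1ccc(-n2cc(OC)cn2)cc1)c1ccc(C(=O)NCCC(=O)O)cc1` gives 1.4, the lowest number of the three measured so far, with compound 2 `CCC(Oc1ccc(-n2cc(C(F)(F)F)cn2)cc1)c1ccc(C(=O)NCCC(=O)O)cc1` at 1.9 and compound 3 `O=C(O)CCNC(=O)c1ccc(C(Oc2ccc(-n3cc(C(F)(F)F)cn3)cc2)C2CCCC2)cc1` at 3.3. Compound 4 `CCCC(Oc1ccc(-n2cc3c(n2)CCCC3)cc1)c1ccc(C(=O)NCCC(=O)O)cc1` keeps the core of compound 1 and changes one group, on an aromatic carbon: a group of 9 heavy atoms (7 carbon, 2 nitrogen; one five-membered aromatic ring with 2 hetero atoms, one six-membered non-aromatic ring of carbon only) in place of a group of 7 heavy atoms (4 carbon, 2 nitrogen, 1 oxygen; one five-membered aromatic ring with 2 hetero atoms), on an aromatic carbon. The entering group holds no oxygen and brings a six-membered non-aromatic ring of carbon only. Going by the values given here, the one measured step that bears on this lies elsewhere in the molecule, cyclopentyl in place of ethyl, which also adds saturated carbon: a number 1.40 log units higher from compound 2 to compound 3 (beyond the scatter). A rise that is somewhat smaller is expected here in this assay, an estimated a number 1.00 log units higher from compound 1 to compound 4 (beyond the scatter). Compound 4 is therefore estimated at 2.4, within a range from 1.9 to 2.9.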

Compound 4, distribution coefficient: 2.7
Estimate against measurement, compound 4: 0.30 log units below, and the stated range covers the measured number.
By their numbers in this assay, from the lowest: compound 1; then compound 2; then compound 4; then compound 3.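

In this assay the swap of 4-methoxy-1H-pyrazol-1-yl for the group with the added six-membered non-aromatic ring gives a number 1.30 log units higher from compound 1 to compound 4 (beyond the scatter) as the first step read at this place. A large step can therefore arise on this aromatic carbon, para to a large group, and not only at the saturated chain carbon. Nothing available explains the size of this step.

Still open, on these data alone, is whether the lost oxygen or the added ring carries the step. Also open, as far as these compounds go, is what this assay would show with an amine or a hydroxyl group in place of the methoxy.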